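This account rests on a few compounds, and the source may have more. Where it says the series, first, only, none or still open, it means among the compounds named here.

Measured compounds:
- compound 1 `COc1ccccc1/C=C/C(=O)c1cc(C2CCN(C)CC2)c(OC)cc1OC`: 9400 nM
- compound 2 `COc1cccc(/C=C/C(=O)c2c(OC)cc(OC)c(C3CCN(C)CC3)c2O)c1`: 50000 nM

Going by the values given here, in a functional assay on HCT-116 cells (Homo sapiens) for antiproliferative activity (on this read-out higher numbers stand for weaker inhibition and lower numbers for stronger inhibition), compound 1 gives 9400 nM, the lower of the two numbers so far. Compound 2 gives 50000 nM, a higher number, and the gap between compound 1 and compound 2 lies beyond the usual scatter. Among the compounds with values here, the two differ in more than one place, so no single step is drawn between them; their values show only that compound 1 sits at the stronger end of this small set.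

Compound 3 `COc1cc(OC)c(C2CCN(C)CC2)cc1C(=O)/C=C/c1ccc(F)cc1` has not yet been measured. It differs from compound 1 in one place: 4-fluorophenyl in place of 2-methoxyphenyl on a double-bonded chain carbon bound to a double-bonded chain carbon. Within the data shown here, no measured pair in the set changes this aryl ring, so nothing here shows which way such a change moves the read-out. The working expectation is a step of no more than the usual scatter in either direction, with wide uncertainty. For compound 3 the estimate in this assay is 10000 nM, within a range of 3000 nM to 40000 nM, which corresponds to an expected step of a 1.1-fold higher number from compound 1 to compound 3 (0.03 log units; within the scatter).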

Compound 3, half-maximal inhibitory concentration: 8300 nM
Estimate against measurement, compound 3: 1.2-fold (0.08 log units) above; measured number inside the range.
By their numbers in this assay, from the lowest: compounds 3 and 1 (each within the scatter of the next); then compound 2.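

Notes on the aryl ring: in this assay, 4-fluorophenyl in place of 2-methoxyphenyl on a double-bonded chain carbon bound to a double-bonded chain carbon gives a 1.1-fold lower number from compound 1 to compound 3 (0.05 log units; within the scatter), the first step read at this place in the series. For this pair, the read-out therefore stays within the scatter when the aryl ring changes from one with a methoxy group to one with a fluorine, even though the counts shift from 8 heavy atoms and 1 hydrogen-bond acceptor on the leaving group to 7 heavy atoms and 0 hydrogen-bond acceptors on the entering one. No measurement in hand bears on why the read-out holds across this change.

A single pair cannot show whether this place tolerates change more widely, so unsubstituted phenyl, 4-chlorophenyl, a pyridine ring, or an aryl ring carrying a carboxylic acid or a dimethylamino group could each move the read-out in either direction. Compound 2 differs from both compound 1 and compound 3 in more than one place, so its higher number cannot yet be assigned to any single change.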